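Phenyl to 2,4-difluorophenyl in compound 3

This account rests on a few compounds, and the source may have more. Where it says the series, first, only, none or still open, it means among the compounds named here.

Measured in an ADME assay on Vero cells (Chlorocebus sabaeus) for cytotoxicity, read by crystal violet staining; a lower number here means that less compound is tolerated, a higher number that more compound is tolerated:
- Compound 1 (`Fc1ccc(F)c(/N=N/c2ccc(NC[C@@H]3CCCN4CCCC[C@H]34)c3c2CCCC3)c1`): 80000 nM
- Compound 2 (`c1ccc(/N=N/c2ccc(NC[C@@H]3CCCN4CCCC[C@H]34)c3c2CCCC3)cc1`): 80000 nM

Level with compound 1, compound 2 stands at 80000 nM in this assay. Compound 3 (`Fc1ccc(/N=N/c2ccc(NC[C@@H]3CCCN4CCCC[C@H]34)c3c2CCCC3)c(F)c1`) carries 2,4-difluorophenyl in place of phenyl on a double-bonded nitrogen. Among the measured compounds shown here, one measured step bears on this change, at the same place: no change at the digits printed from compound 1 to compound 2 (within the scatter). For the measured compounds named here, with only that step to go on, no shift beyond the scatter is expected in this assay, and the expected step is no change at the digits printed from compound 2 to compound 3 (within the scatter). Compound 3 is estimated at 80000 nM, within a range of 40000 nM to 150000 nM.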

Compound 3, half-maximal cytotoxic concentration: 15000 nM
Estimate against measurement, compound 3: 5.3-fold (0.73 log units) above; measured number below the stated range.
By their numbers in this assay, from the lowest: compound 3; then compounds 1 and 2 (each within the scatter of the next).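

In this assay the change to 2,4-difluorophenyl brings a 5.3-fold lower number from compound 2 to compound 3 (0.73 log units; beyond the scatter) and, against the 2,5-difluorophenyl group, a 5.3-fold lower number from compound 1 to compound 3 (0.73 log units; beyond the scatter). So this place on the double-bonded nitrogen is not indifferent to what it carries, and the presence of two fluorines alone does not set the number: compound 1 stands level with compound 2 and compound 3 does not. Nothing available here accounts for this shift. On these data alone, whether a single fluorine, a chlorine or a methoxy group at this place would stand with compound 3 or with compound 1 stays open.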